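This account rests on a few compounds, and the source may have more. Where it says the series, first, only, none or still open, it means among the compounds named here.

For the measured compounds named here, in an ADME assay on THP-1 cells (Homo sapiens) for cytotoxicity, read by trypan blue exclusion, with a stated time of 48 h (on this read-out lower numbers stand for stronger inhibition of growth and higher numbers for weaker inhibition of growth), compound 2 `Cc1cc(CNC2CCCCC2)c(C)n1-c1ccc(Cl)cc1` gives 7.4 ug/mL, the lower of the two numbers so far, clearly apart from compound 1 `Cc1c(CNCc2ccccc2)cc(-c2ccc(Cl)cc2)n1-c1ccc(Cl)cc1` at 99 ug/mL. Compound 3 `Cc1c(CNC2CCCCC2)cc(-c2ccc(Cl)cc2)n1-c1ccc(Cl)cc1` is compound 2 with 4-chlorophenyl in place of methyl on an aromatic carbon. Compound 1 also carries 4-chlorophenyl on that carbon, and its 99 ug/mL points toward a higher number for compound 3. The expected change is a 4.1-fold higher number from compound 2 to compound 3 (0.61 log units; beyond the scatter), toward weaker inhibition of growth and beyond the scatter. The estimate for compound 3 is 30 ug/mL, with an expected range from 9 ug/mL to 100 ug/mL.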

Compound 3, concentration for 50% growth inhibition: 3.9 ug/mL
Estimate against measurement, compound 3: 7.7-fold (0.89 log units) above; measured number outside the range, below it.
By their numbers in this assay, from the lowest: compounds 3 and 2 (each within the scatter of the next); then compound 1.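

In this assay, this aromatic carbon tolerates a much larger group: 4-chlorophenyl in place of methyl gives a 1.9-fold lower number from compound 2 to compound 3 (0.28 log units; within the scatter). The amine nitrogen matters far more, since cyclohexyl in place of benzyl gives a 25-fold lower number from compound 1 to compound 3 (1.40 log units; beyond the scatter), so the high number of compound 1 goes with its benzyl group and not with its 4-chlorophenyl. Nothing shown explains either step. Still open, going by these compounds, is whether a carboxylic acid or a longer alkyl chain on this carbon would be tolerated as well, and whether an ethyl group on the amine nitrogen would behave like cyclohexyl or like benzyl.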